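The compounds below may be only part of what the source reports. "The series", "measured", "known", "first", "only" and "open" are said of these compounds alone.

Working notes on the series.

Compound 1 `Fc1cc(Cl)ccc1-c1ccc(Cn2nnc3ccccc32)cn1` gives 0.8 mL/min/g in an ADME assay on microsomes from liver (Rattus norvegicus, strain Wistar) for metabolic stability, tested at 2.5 uM; on this read-out higher numbers stand for fast clearance and lower numbers for slow clearance. Compound 2 `Clc1ccc(-c2ccc(Cn3nnc4ccccc43)cn2)cc1` gives 1 mL/min/g in this assay. Compound 3 `Clc1ccc(Cn2nnc3c(Br)cccc32)cc1`, which carries a bromo group on its core, gives 2.2 mL/min/g in this assay; its number is the highest of the three, and its gaps to compound 2 and to compound 1 are both beyond the scatter. How the core of compound 3 differs from the core of compound 2 is not broken down here.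

Between compound 2 and compound 1 the change is fluoro in place of hydrogen on an aromatic carbon. The step it made in this assay is a 1.3-fold lower number from compound 2 to compound 1 (0.10 log units; within the scatter), so the change left the number essentially where it was.

Compound 4 `Fc1cc(Cl)ccc1Cn1nnc2c(Br)cccc21` is not yet measured. It differs from compound 3 by fluoro in place of hydrogen on an aromatic carbon, which is the same change as that from compound 2 to compound 1, at a place described in the same words. For the measured compounds named here, with only one earlier instance to rest on, the step from compound 3 to compound 4 is expected to be small, a 1.3-fold lower number from compound 3 to compound 4 (0.11 log units; within the scatter), because the earlier step was a 1.3-fold lower number from compound 2 to compound 1 (0.10 log units; within the scatter). On that basis compound 4 is estimated at 1.7 mL/min/g in this assay, with a range from 0.9 mL/min/g to 3.3 mL/min/g.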

Compound 4, intrinsic clearance in a liver preparation (reported as CLH), per the amount of preparation that the assay uses: 3.8 mL/min/g
For compound 4 the middle estimate is 2.2-fold (0.35 log units) below the measured one; the whole stated range lies below it.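

In this assay the same change, fluoro in place of hydrogen on an aromatic carbon, gave a 1.7-fold higher number from compound 3 to compound 4 (0.24 log units; within the scatter), so on this second core it again stayed within the scatter. Set side by side, the two steps do not differ by more than repeated measurements of this kind allow: the same change on two cores in this assay, a 1.3-fold lower number (0.10 log units; within the scatter) from compound 2 to compound 1 and a 1.7-fold higher number (0.24 log units; within the scatter) from compound 3 to compound 4, 2.2-fold (0.33 log units) apart, within the scatter of two such steps. On these two cores the change therefore carries over as a step too small to read, and the opposite directions of the two steps are no evidence that the core matters, though two pairs cannot show that it would behave the same way on any further core.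

The compounds shown leave open whether a group other than fluoro at this place, such as an amine, a carboxylic acid or a longer chain, would move the number beyond the scatter. For the compounds shown here, they also leave open what the bromo group alone contributes, as no pair here differs by that group only.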